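The source may report more compounds than this note shows. Statements on the series, on what has been measured and on what is new or still open speak of the compounds shown alone.

Measured so far in a functional assay (strain AB) with Danio rerio as the target, read by microscopy, with a stated time of 1 h; a higher number here means that more compound is needed for the effect, a lower number that less compound is needed:

- Compound 1 `CCN1CCc2c(sc(NC=O)c2C(N)=O)C1`: > 25000 nM
- Compound 2 `NC(=O)c1c(NC(=O)Nc2ccc(Cl)cc2)sc2c1CCN(CC1CCC1)C2`: 1360 nM

The entry for compound 1, > 25000 nM, is a limit of the assay and not a number. Among the compounds with values here, compound 2, at 1360 nM, therefore holds the only true number in the set, and no second number exists to rank it against.

The next compound to be tested in this assay is compound 3 `NC(=O)c1c(NC(=O)Nc2ccc(Cl)cc2)sc2c1CCN(CC1CCCC1)C2`. It departs from compound 2 in a single place: cyclopentyl in place of cyclobutyl on a saturated chain carbon bound to an amine nitrogen in a ring. Put in words, cyclopentyl stands in place of cyclobutyl on a saturated chain carbon bound to an amine nitrogen in a ring; the same difference can be read as cyclobutylmethyl to cyclopentylmethyl.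

Within the data shown here, no measured pair in the set shows a change of this kind. The expectation therefore rests on compound 2 at 1360 nM alone, and no step beyond the scatter is expected in either direction. The expected step is a 1.0-fold lower number from compound 2 to compound 3 (0.02 log units; within the scatter). For compound 3 the estimated value is 1300 nM, with an expected range from 450 nM to 3800 nM.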

Compound 3, half-maximal effective concentration: 1830 nM
The estimate for compound 3 lay 1.4-fold (0.15 log units) below the measured number; the measured number falls inside the stated range.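

In this assay, within the data shown here, the change from cyclobutyl to cyclopentyl on a saturated chain carbon bound to an amine nitrogen in a ring gives a 1.3-fold higher number from compound 2 to compound 3 (0.13 log units; within the scatter), and this is the first step in the set that can be read at all. Among these compounds, it shows that this position accepts a five-membered non-aromatic ring in place of a four-membered one without a step beyond the scatter, so the cyclobutylmethyl and cyclopentylmethyl groups cannot be told apart in this read-out, and compound 2 no longer stands as the only true number. No measured property shown here bears on this result.

On these data alone, two closely related carbon rings do not show how much this position will accept, so it remains open whether a cyclohexyl or a phenyl group in the same place, on a saturated chain carbon bound to an amine nitrogen in a ring, would stay within the scatter of compound 2. Compound 1 differs from compound 2 in more than one place, so the compounds shown do not tie what separates them to this position alone.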